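Methylating the amine of the glycinamide side chain

The compounds below may be only part of what the source reports. "The series", "measured", "known", "first", "only" and "open" are said of these compounds alone.

Compound 1 `C=C(c1ccc2c(c1)C=CC(C)(C)O2)c1ccc(OC)cc1NC(=O)CO` and compound 2 `C=C(c1ccc2c(c1)C=CC(C)(C)O2)c1ccc(OC)cc1NC(=O)CN` share one core and differ only at the end of the amide side chain. In a functional assay on HeLa cells (Homo sapiens) for antiproliferative activity, read by MTT assay, with a stated time of 48 h (on this read-out higher numbers stand for weaker inhibition and lower numbers for stronger inhibition), compound 1 gives 100 nM, and compound 2 gives 160 nM. Compound 2 holds the higher of the two numbers, yet the step of a 1.6-fold higher number from compound 1 to compound 2 (0.20 log units; within the scatter) lies within the scatter. Compound 3 `C=C(c1ccc2c(c1)C=CC(C)(C)O2)c1ccc(OC)cc1NC(=O)CNC` carries methyl in place of hydrogen on an amine nitrogen. Among the measured compounds shown here, the only measured step touches the same chain end and was small, so no change beyond the scatter is expected. The expected step is a 1.3-fold higher number from compound 2 to compound 3 (0.10 log units; within the scatter). Compound 3 is estimated at 200 nM, between 80 nM and 500 nM.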

Compound 3, half-maximal inhibitory concentration: 410 nM
Compound 3: middle estimate off by 2.1-fold (0.31 log units), on the low side, within the range that was stated.
By their numbers in this assay, from the lowest: compounds 1 and 2 (each within the scatter of the next); then compound 3.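

A single methyl on the amine nitrogen gives a 2.6-fold higher number from compound 2 to compound 3 (0.41 log units; beyond the scatter) and so marks weaker inhibition, which the earlier change at this chain end, from hydroxy to amino, did not show beyond the scatter. Replacing hydroxy with methylamino gives a 4.1-fold higher number from compound 1 to compound 3 (0.61 log units; beyond the scatter) and shows that this chain end responds to the addition of one carbon. Nothing shown here gives a reason for this shift.

As far as these compounds go, whether a second methyl, as in dimethylamino, or a larger ethylamino group would raise the number further remains open. So does the effect of a carboxylic acid at this chain end.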